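The source may hold more compounds than are shown below. What is called first, only, known or untested is meant among the compounds shown, and "the series" means these compounds.

Of the compounds shown here, two with a shared core have been tested in an assay on HEK293 cells for inhibition of Voltage-dependent T-type calcium channel subunit alpha-1G (Homo sapiens), read by patch clamp, tested at 10 uM; on this read-out lower numbers stand for less inhibition and higher numbers for more inhibition at the one concentration tested (going by the name of the read-out). Compound 1 `COc1ccccc1N1CCN(C[C@H](O)COc2ccc(Cl)cc2)CC1` gives 48.8% in this assay, and compound 2 `O[C@@H](COc1ccc(F)cc1)CN1CCN(c2ccc(F)cc2)CC1` gives 47.5%; the two values lie within the usual scatter of each other. Compound 3 `O[C@@H](COc1ccc(C(F)(F)F)cc1)CN1CCN(c2ccc(F)cc2)CC1` has not yet been measured. It differs from compound 2 by trifluoromethyl in place of fluoro on an aromatic carbon. Within the data shown here, no measured step of this kind is available here, so only a modest change is expected: an estimated step of a number 10.5 percentage points higher from compound 2 to compound 3 (beyond the scatter), about the size of the scatter, toward more inhibition. On that basis compound 3 is expected to give about 58%, with a range from 40% to 78%.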

Compound 3, a percentage reported as inhibition, at one concentration (the size of the read-out at that concentration, not a potency): 53.7%
For compound 3 the middle estimate is 4.3 percentage points above the measured one; the range from low to high includes it.
By their numbers in this assay, from the lowest: compounds 2, 1 and 3 (each within the scatter of the next).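

In this assay, putting trifluoromethyl in place of fluoro on this aromatic carbon, para to a large group, gives a number 6.2 percentage points higher from compound 2 to compound 3 (within the scatter), so with four heavy atoms here in place of one the number stays level within the usual scatter. No measurement available here explains this result.

On these data alone, it remains open how this position would respond to a different kind of group, such as an amine or a carboxylic acid. A single step also cannot show whether the same exchange would give a similar result on another core.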